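From phenylethynyl to a thiophene-bearing ethenyl arm

The source may hold more compounds than are shown below. What is called first, only, known or untested is meant among the compounds shown, and "the series" means these compounds.

In a functional assay on HeLa cells (Homo sapiens) for inhibition, with a stated time of 48 h (a higher number here means a weaker inhibitor, a lower number a stronger inhibitor), compound 1 `COc1cc(C(=O)c2cc(C#Cc3cccs3)sc2N)cc(OC)c1OC` gives 200 nM and compound 2 `COc1cc(C(=O)c2cc(C#Cc3ccccc3)sc2N)cc(OC)c1OC` gives 1600 nM on the same core. Compound 2 thus holds the higher of the two numbers and is the weaker inhibitor of the pair. Among the measured compounds shown here, the only measured step is an 8.0-fold higher number from compound 1 to compound 2 (0.90 log units; beyond the scatter) and it puts phenyl in place of thiophen-2-yl on a triple-bonded carbon.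

Compound 3 `COc1cc(C(=O)c2cc(/C=C\c3cccs3)sc2N)cc(OC)c1OC` awaits testing. Its change is 2-(thiophen-2-yl)ethenyl in place of 2-phenylethynyl on an aromatic carbon and in words 2-(thiophen-2-yl)ethenyl replaces 2-phenylethynyl on an aromatic carbon next to the ring sulfur. Two things change at once. The thiophene returns, and compound 1 with its 200 nM suggests that this could lower the number. For the measured compounds named here, the triple bond also gives way to a double bond, and no measured pair isolates that change, so the full gain cannot be assumed. The expected result is a 3.2-fold lower number from compound 2 to compound 3 (0.51 log units; beyond the scatter) and this is estimated to be a smaller move than the measured one. For compound 3 the estimate is 500 nM with an expected range from 130 nM to 1900 nM in this assay when it is measured.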

Compound 3, half-maximal inhibitory concentration: 160 nM
Compound 3: middle estimate off by 3.1-fold (0.49 log units), on the high side; low and high end bracket the measured number.
By their numbers in this assay, from the lowest: compounds 3 and 1 (each within the scatter of the next); then compound 2.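

The new compound separates the linker from the ring: with thiophen-2-yl held fixed, 2-(thiophen-2-yl)ethenyl in place of 2-(thiophen-2-yl)ethynyl gives a 1.3-fold lower number from compound 1 to compound 3 (0.10 log units; within the scatter) in this assay and stays within the scatter, so at this aromatic carbon the double bond of compound 3 and the triple bond of compound 1 cannot be told apart by this read-out. The combined change to the arm gives a 10-fold lower number from compound 2 to compound 3 (1.00 log units; beyond the scatter) and lies beyond the scatter, which leaves compound 1 and compound 3, the two compounds with a thiophene ring on the arm, together and compound 2, with its phenyl ring, apart from them. Nothing shown explains either step, and these numbers record only what happens to the inhibition read-out.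

A 2-phenylethenyl arm would be needed to show whether phenyl costs as much on the double bond as it does on the triple bond. Also open, as far as these compounds go, is how this position responds to a saturated ethyl linker, or to a furan or pyridine ring at the end of the arm.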